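A Phenoxy Swap on an Anti-Inflammatory Core

The source may report more compounds than this note shows. Statements on the series, on what has been measured and on what is new or still open speak of the compounds shown alone.

Compound 1 `O=C(NCc1nn2c(Cc3ccccc3)nnc2s1)c1ccccc1` carries a benzyl group on its core. Going by the values given here, in a functional assay on the whole organism (strain Wistar) for inhibition, with Rattus norvegicus as the target, read by paw edema, with stated times of 30 min and 3 h, at a dose of 20 mg/kg by the oral route (on this read-out higher numbers stand for more inhibition at the one dose given (going by the name of the read-out) and lower numbers for less inhibition), compound 1 gives 28%, the lowest of the two numbers measured so far. Compound 2 `c1ccc(Cc2nnc3sc(-c4ccccc4Oc4ccccc4)nn23)cc1` is built differently in several places, and in this assay compound 2 gives 56.3%, a reading that lies beyond the usual scatter above that of compound 1; since the two compounds differ in more than one place, their two values show only that this gap exists.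

Compound 3 `O=C(NCc1nn2c(COc3ccccc3)nnc2s1)c1ccccc1` has not yet been measured. It differs from compound 1 in one place: phenoxy in place of phenyl on a saturated chain carbon bound to an aromatic carbon Cut one bond further out, the same change reads benzyl to phenoxymethyl. Among the compounds with values here, no measured pair shows this change, so the step from compound 1 to compound 3 is estimated as small and upward, a number 6 percentage points higher from compound 1 to compound 3 (within the scatter), roughly within the scatter. Compound 3 is therefore expected to give 34% in this assay, with a range from 15% to 55%.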

Compound 3, a percentage reported as inhibition, in the whole organism at one dose (the size of the read-out at that dose, not a potency): 37.2%
Compound 3: middle estimate off by 3.2 percentage points, on the low side, and the stated range covers the measured number.
By their numbers in this assay, from the lowest: compounds 1 and 3 (each within the scatter of the next); then compound 2.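

Going by these compounds alone, compound 1 and compound 3 form the first pair here that differs in only one place, so they give the first direct look at this position, which the gap to compound 2 could not provide. In this assay, phenoxy in place of phenyl on a saturated chain carbon bound to an aromatic carbon gives a number 9.2 percentage points higher from compound 1 to compound 3 (within the scatter), so adding the oxygen, with its one hydrogen-bond acceptor, leaves the two compounds indistinguishable on this read-out. Nothing available gives a reason for this reading.

As far as these compounds go, it remains open whether a different group at this place, such as an amine, a carboxylic acid or a longer chain, would give a step beyond the scatter. From the compounds shown here alone, it is also open whether the same swap would give a similar step on compound 2, which also carries benzyl.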